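Swapping Chloro for Fluoro on a Weak Compound

The compounds below may be only part of what the source reports. "The series", "measured", "known", "first", "only" and "open" are said of these compounds alone.

Compound 1 `O=C1NC(=O)N(/N=C/c2ccc(-c3ccc(Cl)cc3)o2)C1O` gives > 1000 mg/kg (a limit)
Compound 2 `O=C1CN(/N=C/c2ccc(-c3cccc(C(F)(F)F)c3)o2)C(=O)N1` gives 647 mg/kg (a number)

Both compounds were tested in a functional assay on the whole organism for activation, with Mus musculus as the target, with a stated time of 60 min (on this read-out higher numbers stand for an effect only at larger amounts of compound and lower numbers for an effect already at smaller amounts), and a small dose needed there would mean a strong effect. Compound 1 gives > 1000 mg/kg in that test, which is a limit of the assay and not a true number. Its real value is therefore unknown. Compound 2 gives 647 mg/kg as a measured number.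

Compound 3 `O=C1NC(=O)N(/N=C/c2ccc(-c3ccc(F)cc3)o2)C1O` keeps the core of compound 1 and has fluoro in place of chloro on an aromatic carbon. The change sits on a six-membered aromatic ring of carbon only, para to a large group, and turns 4-chlorophenyl into 4-fluorophenyl.

Within the data shown here, no measured pair here shows what this swap does, so the expectation rests on compound 1 at > 1000 mg/kg alone. The expected step of a number no higher from compound 1 to compound 3 (the limit leaves the size open) is none beyond the usual scatter, in either direction. In this assay compound 3 is expected at 1000 mg/kg with an estimated range from 400 mg/kg to 2500 mg/kg for the measurement.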

Compound 3, dose for half-maximal effect: > 1000 mg/kg
Compound 3 gave a limit, no number; the forecaster's own chance of this, stated with the estimate: 50%; the middle value lies on the limit itself.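

Compound 1 and compound 3 each give only a limit and not a number, and no step from one to the other can be read: the limit of > 1000 mg/kg in this assay, at which 2 of the 3 values shown sit.

The compounds shown leave open whether fluoro in place of chloro changes the dose needed at all, and where the true values of compound 1 and compound 3 lie.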